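The source may report more compounds than this note shows. Statements on the series, on what has been measured and on what is new or still open speak of the compounds shown alone.

Compound 3 `O=C(O)CCCC/C=C(\c1cccnc1)c1cccs1` gives the lowest number of the three measured in an assay (Equus caballus) for inhibition of Thromboxane-A synthase (Homo sapiens), using microsomes (a lower number here means a stronger inhibitor, a higher number a weaker inhibitor), with 20 nM; compound 2 `O=C(O)CCCC/C=C(/c1cccnc1)c1ccsc1` follows at 62 nM, and compound 1 `C/C(=C\CCCCC(=O)O)c1cccnc1` gives 210 nM. Compound 4 `O=C(O)CCCC/C=C(/c1cccnc1)c1cccs1` keeps every atom and bond of compound 3 and changes only the drawn geometry of the double bond: the two compounds have the same atoms and bonds and differ only in configuration as drawn: 1 of 1 stereo elements differ; a double bond is drawn E in compound 3 and Z in compound 4. No measured step involves such a switch; the single step shown, a 3.4-fold lower number from compound 1 to compound 2 (0.53 log units; beyond the scatter), swaps one group for another and so offers no direct guide. Since a changed geometry reshapes the whole molecule, a step beyond the scatter is plausible in either direction, with weakening somewhat more likely. Compound 4 is therefore expected near 60 nM, within a wide range from 10 nM to 400 nM, a step of a 3.0-fold higher number from compound 3 to compound 4 (0.48 log units; beyond the scatter).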

Compound 4, half-maximal inhibitory concentration: 54 nM
Compound 4: middle estimate off by 1.1-fold (0.05 log units), on the high side; low and high end bracket the measured number.
By their numbers in this assay, from the lowest: compound 3; then compounds 4 and 2 (each within the scatter of the next); then compound 1.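

Changing only the geometry of the double bond moves the number, a 2.7-fold higher number from compound 3 to compound 4 (0.43 log units; beyond the scatter), and this gap can be assigned to that geometry because of one fact: the fact that compounds 3 and 4 differ only in the configuration as drawn. With the double bond drawn alike, exchanging one thiophene attachment for the other has no clear effect, a 1.1-fold lower number from compound 2 to compound 4 (0.06 log units; within the scatter). Thiophen-2-yl still improves on methyl, a 3.9-fold lower number from compound 1 to compound 4 (0.59 log units; beyond the scatter).

On these data alone, it remains open whether thiophen-3-yl responds to the same switch in geometry. Also open, as far as these compounds go, is whether a phenyl group in place of the thiophene, or an amide in place of the carboxylic acid, would keep these numbers.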